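The source may hold more compounds than are shown below. What is called first, only, known or untested is meant among the compounds shown, and "the series" means these compounds.

Measured in an ADME assay on microsomes from liver (Homo sapiens) for pharmacokinetics, read by LC-MS, with a stated time of 60 min, tested at 1 uM; a lower number here means slower removal, a higher number faster removal of the compound:
compound 1 `Nc1ccc(CNC(=O)Nc2ccc(S(=O)(=O)c3ccccc3)cc2)cn1`: 5 mL/min/kg
compound 2 `C[C@@H]1CN(S(=O)(=O)c2ccc(NC(=O)NCc3cccnc3)cc2)C[C@H](C)O1`: 17 mL/min/kg
compound 3 `C[C@@H]1COC[C@@H](C)N1S(=O)(=O)c1ccc(NC(=O)NCc2cccnc2)cc1`: 17 mL/min/kg

Compound 2 stands level with compound 3 at the top of this small set, and the lowest number belongs to compound 1. Compound 4 `CC1CCN(S(=O)(=O)c2ccc(NC(=O)NCc3cccnc3)cc2)CCN1` departs from compound 2 on the sulfonyl sulfur: a group of 8 heavy atoms (6 carbon, 2 nitrogen; one seven-membered non-aromatic ring with 2 hetero atoms) in place of a group of 8 heavy atoms (6 carbon, 1 nitrogen, 1 oxygen; one six-membered non-aromatic ring with 2 hetero atoms), on a sulfonyl sulfur. Among the compounds with values here, the only measured step at that place is no change at the digits printed from compound 2 to compound 3 (within the scatter). Within the data shown here, that step keeps a six-membered ring, so it bears on the new ring only loosely, and no measured step covers such a ring change. No shift beyond the scatter is therefore expected in this assay. The expected step is a 1.1-fold lower number from compound 2 to compound 4 (0.05 log units; within the scatter). For compound 4 the estimated clearance is 15 mL/min/kg, with an expected range of 7 mL/min/kg to 30 mL/min/kg.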

Compound 4, clearance: 5 mL/min/kg
Compound 4: middle estimate off by 3.0-fold (0.48 log units), on the high side; measured number below the stated range.
By their numbers in this assay, from the lowest: compounds 1 and 4 (each within the scatter of the next); then compounds 2 and 3 (each within the scatter of the next).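

In this assay, the place on the sulfonyl sulfur proves able to shift clearance: the seven-membered ring gives a 3.4-fold lower number from compound 2 to compound 4 (0.53 log units; beyond the scatter) and also a 3.4-fold lower number from compound 3 to compound 4 (0.53 log units; beyond the scatter), whereas moving the methyl groups around the six-membered ring gave no change at the digits printed from compound 2 to compound 3 (within the scatter). Nothing available explains this drop. The entering group differs from the 2,6-dimethylmorpholin-4-yl group in both ring size and hetero atoms, so the shift cannot be assigned to either one. A 1,4-oxazepane ring or a piperazine ring on the same sulfur would separate the two, and the compounds shown leave that open.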